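The source may hold more compounds than are shown below. What is called first, only, known or untested is meant among the compounds shown, and "the series" means these compounds.

Within the data shown here, in a functional assay on Rec1 cells (Homo sapiens) for inhibition, read by luminescence and CellTiter-Glo, with a stated time of 72 h (on this read-out higher numbers stand for weaker inhibition and lower numbers for stronger inhibition), compound 2 `CCOC(=O)c1cc(-c2ccc(Oc3ccccc3)cc2)nn1Cc1cccc(NC(=O)CCl)c1` gives 400 nM, the lowest of the three numbers so far. Its gaps to compound 1 `C/C=C/C(=O)Nc1ccc(Cn2nc(-c3ccc(Oc4ccccc4)cc3)cc2C(=O)O)cc1`, at 23600 nM, and to compound 3 `C=CC(=O)N1CCCC(n2nc(-c3ccc(Oc4ccccc4)cc3)cc2C(=O)O)C1`, at 50000 nM, both lie beyond the usual scatter. Compound 4 `C=CC(=O)Nc1cccc(Cn2nc(-c3ccc(Oc4ccccc4)cc3)cc2C(=O)OCC)c1` makes one small change to compound 2: vinyl in place of chloromethyl on a carbonyl carbon. Among the measured compounds shown here, neither compound 1 nor compound 3 differs from compound 2 in one place only, so no measured pair shows what this swap does and the expectation remains loose. A moderate rise in the number, meaning weaker inhibition, is expected, with an estimated step of a 3.8-fold higher number from compound 2 to compound 4 (0.57 log units; beyond the scatter). For compound 4 the estimated value is 1500 nM, with an expected range of 300 nM to 8000 nM.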

Compound 4, half-maximal inhibitory concentration: 3300 nM
Beside the measured number, compound 4's estimate is 2.2-fold (0.34 log units) below it; the range from low to high includes it.
By their numbers in this assay, from the lowest: compound 2; then compound 4; then compound 1; then compound 3.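

In this assay, putting vinyl in place of chloromethyl on the carbonyl carbon gives an 8.3-fold higher number from compound 2 to compound 4 (0.92 log units; beyond the scatter). Among these compounds, this is the first comparison here that changes one place only, and it shows that this place matters: two groups with the same heavy-atom count, neither carrying a ring, give clearly different numbers. Nothing available here explains the difference. Still open, going by these compounds, is where a plain methyl or a longer chain on the same carbonyl carbon would fall, whether nearer compound 2 or nearer compound 4.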